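Removing the Cyclohexyl Group and Tolerated Concentration

A few compounds are considered here, and "the series" means these few. Any claim that something is new, unique, unknown or untested is made for them only; others in the source may bear on it.

Compound 1, `COc1ccc(-c2nc3cc(/C(C)=N/NC(N)=O)ccc3[nH]2)cc1`, gives 25000 nM in an ADME assay on MDBK cells (Bos taurus) for cytotoxicity, read by MTT assay, with a stated time of 96 h; a lower number here means that less compound is tolerated, a higher number that more compound is tolerated.
Compound 2, `COc1ccc(-c2nc3cc(/C(C)=N/NC(N)=O)ccc3n2C2CCCCC2)cc1`, gives 54000 nM in this assay.
Compound 3, `C/C(=N\NC(N)=S)c1ccc2c(c1)nc(-c1ccoc1)n2C1CCCCC1`, gives only a limit of the assay, > 100000 nM, in this assay.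

Compound 1 differs from compound 2 by hydrogen in place of cyclohexyl on an aromatic nitrogen. That change brought a 2.2-fold lower number from compound 2 to compound 1 (0.33 log units; beyond the scatter). How the core of compound 3 differs from the core of compound 2 is not broken down here. Compound 4, `C/C(=N\NC(N)=S)c1ccc2[nH]c(-c3ccoc3)nc2c1`, is not yet measured and differs from compound 3 by hydrogen in place of cyclohexyl on an aromatic nitrogen. The surroundings differ: the ring atom next to the aromatic nitrogen bears a furan-3-yl group in compound 3 but a 4-methoxyphenyl group in compound 2, so this is the same kind of change, not the same change. Because compound 3 sits at the limit of > 100000 nM in this assay, at which 1 of the 3 values shown sits, its starting point is uncertain. The expected step is an at least 1.6-fold lower number from compound 3 to compound 4 (0.22 log units; that floor lies within the scatter), resting on a 2.2-fold lower number from compound 2 to compound 1 (0.33 log units; beyond the scatter). Compound 4 is therefore expected to give about 60000 nM, between 25000 nM and 150000 nM.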

Compound 4, half-maximal cytotoxic concentration: > 100000 nM
Compound 4: a limit, no number (the forecaster's own chance of this, stated with the estimate: 40%); middle value at least 1.6-fold (0.22 log units) away from the limit.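

Compound 3 and compound 4 each give only a limit in this assay, not a number, so the step between them cannot be read: the limit of > 100000 nM in this assay, at which 2 of the 4 values shown sit.

From the compounds shown here alone, whether hydrogen in place of cyclohexyl lowers the number in compounds bearing the furan-3-yl group, as it does from compound 2 to compound 1, stays open.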